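The source may hold more compounds than are shown below. What is called first, only, known or untested is meant among the compounds shown, and "the series" means these compounds.

Of the compounds shown here, three have so far been measured in an assay on HEK293 cells for agonist activity at transient receptor potential cation channel subfamily M member 8 (Homo sapiens), read by fluorescence and calcium flux, with a stated time of 15 min; a lower number here means that less compound is needed, a higher number that more compound is needed for the effect. Compound 1 `CCN(Cc1ccco1)C(=O)COc1ccc(C)cc1` gives 489 nM in this assay. Compound 2 `Cc1ccc(OCC(=O)N(Cc2cccs2)c2ccnn2C)cc1` gives 422 nM, a number within the usual scatter of that of compound 1, so no order can be drawn between these two. Compound 3 `CCN(Cc1cccs1)C(=O)c1cc2cc(C)ccc2[nH]1` gives 2010 nM, a higher number that lies beyond the scatter relative to compound 1. Among the three, compound 1 therefore holds the second highest number, close to compound 2 and well apart from compound 3. Going by the values given here, no two measured compounds differ in a single place, so no direct step between measured compounds is available.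

Compound 4 `CCN(Cc1c[nH]nn1)C(=O)COc1ccc(C)cc1` differs from compound 1 in one place: 1H-1,2,3-triazol-4-yl in place of furan-2-yl on a saturated chain carbon bound to an amide-type nitrogen. Among the compounds with values here, no measured pair shows this change, so its effect must be judged from compound 1 alone. The step of a 1.8-fold higher number from compound 1 to compound 4 (0.26 log units; within the scatter) is expected to be a modest rise in the number, small enough that it may not exceed the scatter. Compound 4 is accordingly expected to give 900 nM, with a range from 300 nM to 3000 nM.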

Compound 4, half-maximal effective concentration: 31100 nM
Estimate against measurement, compound 4: 35-fold (1.54 log units) below, outside the stated range (above it).
By their numbers in this assay, from the lowest: compounds 2 and 1 (each within the scatter of the next); then compound 3; then compound 4.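

The furan-2-yl group on this saturated chain carbon turns out not to be freely exchangeable: in this assay, 1H-1,2,3-triazol-4-yl in its place gives a 64-fold higher number from compound 1 to compound 4 (1.80 log units; beyond the scatter), a large step for a swap that keeps the five heavy atoms and the five-membered aromatic ring. What changes is the ring's content: three hetero atoms instead of one, with a hydrogen-bond donor where the furan has none. Nothing at hand explains the size of this step.

On these data alone, it remains open which of these differences carries the step, and whether any other ring at this place keeps the number near that of compound 1. A triazole bearing a methyl group on its ring nitrogen, or a plain phenyl ring, would help to separate these possibilities.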